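This account rests on a few compounds, and the source may have more. Where it says the series, first, only, none or still open, it means among the compounds named here.

Values in a functional assay on MCF7 cells (Homo sapiens) for antiproliferative activity, read by CellTiter-Glo, with a stated time of 5 days; on this read-out higher numbers stand for weaker inhibition and lower numbers for stronger inhibition:

- Compound 1 `CC/C(=C(/c1ccc(/C=C/C(=O)O)cc1)c1ccc2c(cnn2C)c1)c1ccc(F)cc1Cl`: 81 nM
- Compound 2 `CC/C(=C(/c1ccc(/C=C/C(=O)O)cc1)c1ccc2nccn2c1)c1ccccc1`: 170 nM
- Compound 3 `CC/C(=C(/c1ccc(/C=C/C(=O)O)cc1)c1ccn2nncc2c1)c1ccccc1`: > 500 nM (a limit, not a number)

Compound 3 stands at the limit of > 500 nM in this assay, at which 1 of the 3 values shown sits. It therefore gives no exact starting point for the next step.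

Compound 4 `CC/C(=C(/c1ccc(/C=C/C(=O)O)cc1)c1ccc2ccccc2c1)c1ccccc1` is the next member to consider. The change is a group of 10 heavy atoms (10 carbon; 2 six-membered aromatic rings of carbon only) in place of a group of 9 heavy atoms (6 carbon, 3 nitrogen; one five-membered aromatic ring with 3 hetero atoms, one six-membered aromatic ring with 1 hetero atom), on a double-bonded chain carbon bound to an aromatic carbon and a double-bonded chain carbon. The group that leaves has no common name, and the one that enters is naphthalen-2-yl, on a double-bonded chain carbon bound to an aromatic carbon and a double-bonded chain carbon.

Within the data shown here, only one measured step bears directly on this place: an at least 2.9-fold higher number from compound 2 to compound 3 (0.46 log units; beyond the scatter). It lies beyond the scatter, so a swap of groups here can move the number in this assay. Among the measured compounds shown here, it does not show how an all-carbon group will behave, as no compound measured so far carries one at this place. Compound 2 gives 170 nM, and compound 1, which also differs elsewhere, gives 81 nM. Both are numbers clear of the limit, so a return to that range is expected, with wide uncertainty.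

The estimate means an expected at least 4.1-fold lower number from compound 3 to compound 4 (0.61 log units; beyond the scatter), towards stronger inhibition. For compound 4 the expected value is 120 nM, with an estimated range of 30 nM to 450 nM.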

Compound 4, half-maximal inhibitory concentration: 180 nM
Compound 4: middle estimate off by 1.5-fold (0.18 log units), on the low side; the measured number falls inside the stated range.
By their numbers in this assay, from the lowest: compound 1; then compounds 2 and 4 (each within the scatter of the next). At a limit, above all of these: compound 3.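

In this assay, the all-carbon naphthalen-2-yl group at this place, on a double-bonded chain carbon bound to an aromatic carbon and a double-bonded chain carbon, gives an at least 2.7-fold lower number from compound 3 to compound 4 (0.44 log units; beyond the scatter), so a group with no hydrogen-bond acceptors brings the number back out of the limit range. The starting point of that step is a limit held by compound 3, not a number, and the true size of the step stays unknown: the limit of > 500 nM in this assay, at which 1 of the 4 values shown sits.

Set against the group of compound 2, the same group gives a 1.1-fold higher number from compound 2 to compound 4 (0.02 log units; within the scatter), so ring nitrogen in this group is not required for a number in this range, and among these three groups only the one in compound 3 stands apart.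

From the compounds shown here alone, it remains open which feature of the group in compound 3 separates it from the other two, and whether a smaller group such as plain phenyl, or a naphthalen-2-yl group carrying an amine or a hydroxyl, would hold this range. Compound 1, at 81 nM, differs from the others in more than one place, so the share of its chloro and fluoro substituents cannot be separated from that of its bicyclic group.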